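One group swapped on a sulfonamide nitrogen

The source may hold more compounds than are shown below. What is called first, only, known or untested is meant among the compounds shown, and "the series" means these compounds.

Going by the values given here, in a physicochemical assay for lipophilicity, at pH 7.4 (a lower number here means a more polar compound, a higher number a more lipophilic compound), two compounds sharing one core have numbers so far. Compound 1 (`CC(C)CN(c1ccc(C(C)(C)C)cc1)S(=O)(=O)c1ccc2c(c1)C(=O)CC(C1CCOCC1)O2`) gives 4.97 here, and compound 2 (`CC(C)CN(c1cc2ccccc2s1)S(=O)(=O)c1ccc2c(c1)C(=O)CC(C1CCOCC1)O2`) gives 4.01 as the lower of the two, with a gap beyond the usual scatter.

Compound 3 (`CC(C)CN(c1ccccc1F)S(=O)(=O)c1ccc2c(c1)C(=O)CC(C1CCOCC1)O2`) has no number yet and differs from compound 2 in one place (2-fluorophenyl in place of 1-benzothiophen-2-yl on a sulfonamide nitrogen), with 2-fluorophenyl in place of 1-benzothiophen-2-yl on a sulfonamide nitrogen.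

Among the compounds with values here, the one measured step that bears on this is a number 0.96 log units lower from compound 1 to compound 2 (beyond the scatter) and it is a modest change, also made on a sulfonamide nitrogen. It is a single example, and the group leaving there is not the group leaving here, so it offers only a rough guide. The group entering now has fewer heavy atoms than the one it replaces, so a further fall is expected. A smaller step than the measured one is expected, and the estimate is a number 0.41 log units lower from compound 2 to compound 3 (beyond the scatter) in the same downward direction. For compound 3 the estimated value is 3.6 with an expected range from 3.1 to 4.1 as the likely span.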

Compound 3, distribution coefficient: 3.44
Beside the measured number, compound 3's estimate is 0.16 log units above it; the range from low to high includes it.
By their numbers in this assay, from the lowest: compound 3; then compound 2; then compound 1.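

In this assay, the group on the sulfonamide nitrogen has now been changed twice from the same starting series, and the step from the benzothiophene compound is a number 0.57 log units lower from compound 2 to compound 3 (beyond the scatter). Measured against the 4-(tert-butyl)phenyl compound, the same 2-fluorophenyl group gives a number 1.53 log units lower from compound 1 to compound 3 (beyond the scatter), a large step and the widest gap seen so far from a change in this one place. With the rest of the molecule unchanged, a single six-membered aromatic ring carrying fluorine thus gives the lowest number of the three, beyond the scatter from both other compounds, and the number at this position has now fallen with two different groups in place of the 4-(tert-butyl)phenyl group.

No measurement shown gives a reason for these shifts. The compounds also do not separate the contribution of the fluorine from that of the ring it sits on, so the number for a plain phenyl group, or for a ring carrying an amine or a carboxylic acid, remains an open question.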